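Swapping Chloro for Trifluoromethyl on the Shared Core

A few compounds are considered here, and "the series" means these few. Any claim that something is new, unique, unknown or untested is made for them only; others in the source may bear on it.

Compound 1 `CCC(=O)N(c1cccc(C)c1)C1CCCC1N(C)C`: 25 mg/kg; 25 mg/kg (2 entries)
Compound 2 `CCC(=O)N(c1cccc(F)c1)C1CCCC1N(C)C`: 5 mg/kg
Compound 3 `CCC(=O)N(c1cccc(Cl)c1)C1CCCC1N(C)C`: 20 mg/kg

All three compounds were tested in a functional assay on the whole organism for positive allosteric modulation, with Mus musculus as the target; a higher number here means that more compound is needed for the effect, a lower number that less compound is needed. Compound 3, at 20 mg/kg, stands well clear of compound 2, whose value is 5 mg/kg. Its value lies within the usual scatter of that of compound 1, at 25 mg/kg; 25 mg/kg (2 entries).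

Compound 4 `CCC(=O)N(c1cccc(C(F)(F)F)c1)C1CCCC1N(C)C` carries trifluoromethyl in place of chloro on an aromatic carbon, meta to a large group: trifluoromethyl in place of chloro on an aromatic carbon.

Among the compounds with values here, the only measured step that bears on this change is a 4.0-fold higher number from compound 2 to compound 3 (0.60 log units; beyond the scatter), a modest one, for chloro in place of fluoro on an aromatic carbon. Within the data shown here, no measured pair sets trifluoromethyl against any other group, so that step gives only a rough idea of how far such a swap can move the number, and no firm direction. No shift beyond the scatter is therefore expected, and the expected change is a 1.3-fold higher number from compound 3 to compound 4 (0.10 log units; within the scatter). For compound 4 the estimated value is 25 mg/kg. The expected range for compound 4 runs from 8 mg/kg to 60 mg/kg.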

Compound 4, dose for half-maximal effect: 0.9 mg/kg
For compound 4 the middle estimate is 28-fold (1.44 log units) above the measured one; measured number below the stated range.
By their numbers in this assay, from the lowest: compound 4; then compound 2; then compound 3.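

In this assay, within the data shown here, this position on the aromatic ring proves far more sensitive than the earlier compounds showed: trifluoromethyl in place of chloro gives a 22-fold lower number from compound 3 to compound 4 (1.35 log units; beyond the scatter), a larger step than the only one seen before. The shift also holds against the fluoro compound, with a 5.6-fold lower number from compound 2 to compound 4 (0.74 log units; beyond the scatter), so the number reached by compound 2 does not mark the low end of what this position allows. No evidence is available to account for the size of this change.

On these data alone, it remains open whether the low number belongs to trifluoromethyl alone or extends to other groups at this place, such as a nitrile or a methoxy group. As far as these compounds go, it is also open whether the step would persist with a longer chain on the carbonyl of the shared core.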